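Methylating the phenol of an anilide cytotoxicity series

The compounds below may be only part of what the source reports. "The series", "measured", "known", "first", "only" and "open" are said of these compounds alone.

Three anilides have been tested in an ADME assay on HEK293 cells (Homo sapiens) for cytotoxicity, read by reporter gene assay and resazurin assay, with a stated time of 48 h (on this read-out lower numbers stand for higher toxicity in this test and higher numbers for lower toxicity in this test), so far. Compound 3 `O=C(Nc1cccc(Cl)c1)c1cc(Br)cc(Br)c1O` gives 18000 nM in this assay, the lowest of the two numbers reported and therefore the most toxic of the measured pair. Compound 2 `O=C(Nc1ccccc1)c1cccc(Br)c1O` gives 82000 nM, a gap to compound 3 that lies beyond the usual scatter. Compound 1 `COc1c(Br)cc(Br)cc1C(=O)Nc1ccccc1`, which also carries a methoxy group, reaches only the assay limit of > 100000 nM, so no number is known for it, as noted in the limit of > 100000 nM in this assay, at which 1 of the 3 values shown sits.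

Compound 4 `COc1c(Br)cc(Br)cc1C(=O)Nc1cccc(Cl)c1` is not yet measured. It differs from compound 3 by methyl in place of hydrogen on an oxygen on an aromatic ring. Within the data shown here, no measured pair shows this exact change, so its size cannot be read directly. Compound 1 sitting at the limit suggests that the methoxy anilide is expected to be less toxic than compound 3, giving a step from compound 3 to compound 4 of a 3.3-fold higher number from compound 3 to compound 4 (0.52 log units; beyond the scatter). Compound 4 is therefore estimated at 60000 nM, with a likely range from 20000 nM to 180000 nM, and a fair chance that this assay reports only a limit.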

Compound 4, half-maximal cytotoxic concentration: > 100000 nM
Compound 4: a limit, no number; the forecaster's own chance of this, stated with the estimate: 35%; middle value at least 1.6-fold (0.22 log units) from the limit.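

Hydroxy to methoxy on the aromatic ring now has a measured size: in this assay this change gives an at least 5.5-fold higher number from compound 3 to compound 4 (0.74 log units; beyond the scatter) and so points to lower toxicity in this test. Among these compounds, earlier, no two compounds differed only at this oxygen, so the comparison of compound 3 and compound 4 is the first direct reading of the change. Compound 4 gives a limit and not a number, so its step is only a minimum, and the step for chloro in place of hydrogen from compound 1 to compound 4 cannot be read because both values are limits: the limit of > 100000 nM in this assay, at which 2 of the 4 values shown sit.

From the compounds shown here alone, on this oxygen only hydrogen and methyl appear, so it remains open how a longer chain such as ethyl would read. Going by these compounds, it also remains open whether an amine in place of the hydroxy would raise the number as methoxy does.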